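The source may hold more compounds than are shown below. What is called first, only, known or untested is meant among the compounds shown, and "the series" means these compounds.

In an ADME assay on CHO cells (Cricetulus griseus) for cytotoxicity, read by MTT assay, with a stated time of 72 h (on this read-out lower numbers stand for higher toxicity in this test and higher numbers for lower toxicity in this test), three compounds have been measured so far.

compound 1 `CCOC(=O)c1c(-c2ccccc2)oc2ccc(OCCCN3C(=O)C(=O)c4ccccc43)cc12` gives 256000 nM in this test
compound 2 `CCOC(=O)c1c(-c2ccc(F)cc2)oc2ccc(OCCCN3C(=O)C(=O)c4ccccc43)cc12` gives 256000 nM in this test
compound 3 `CCOC(=O)c1c(-c2ccccc2)oc2ccc(OCCCN3C(=O)/C(=N/O)c4ccccc43)cc12` gives 512000 nM in this test

The value of compound 3 lies within the usual scatter of both other values, so the three cannot be ranked here. Compound 4 `CCOC(=O)c1c(-c2ccc(F)cc2)oc2ccc(OCCCN3C(=O)/C(=N/O)c4ccccc43)cc12` differs from compound 3 by one change, fluoro in place of hydrogen on an aromatic carbon and so turns phenyl to 4-fluorophenyl. The same change was measured once, as no change at the digits printed from compound 1 to compound 2 (within the scatter) and on this single example no step beyond the scatter is expected in this assay this time. The other measured step, a 2.0-fold higher number from compound 1 to compound 3 (0.30 log units; within the scatter) involves a different group and offers no direct guide. The expected step is a 1.1-fold lower number from compound 3 to compound 4 (0.06 log units; within the scatter) and thus a small one. For compound 4 the estimated value is 450000 nM with an expected range from 220000 nM to 900000 nM in this test.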

Compound 4, half-maximal cytotoxic concentration: 256000 nM
Compound 4: middle estimate off by 1.8-fold (0.24 log units), on the high side; the range from low to high includes it.
By their numbers in this assay, from the lowest: compounds 1, 2, 4 and 3 (each within the scatter of the next).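

In this assay, the change from phenyl to 4-fluorophenyl can now be read on a second core, with a 2.0-fold lower number from compound 3 to compound 4 (0.30 log units; within the scatter), and the two readings agree: the same change on two cores in this assay, no change at the digits printed (within the scatter) from compound 1 to compound 2 and a 2.0-fold lower number (0.30 log units; within the scatter) from compound 3 to compound 4, 2.0-fold (0.30 log units) apart, within the scatter of two such steps. The exchange of the group on the saturated chain carbon can also be read twice, with no change at the digits printed from compound 2 to compound 4 (within the scatter), and these readings agree as well: the same change on two cores in this assay, a 2.0-fold higher number (0.30 log units; within the scatter) from compound 1 to compound 3 and no change at the digits printed (within the scatter) from compound 2 to compound 4, 2.0-fold (0.30 log units) apart, within the scatter of two such steps. Neither change has yet moved the number beyond the scatter on either core.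

The compounds shown carry only hydrogen or fluoro on that aromatic carbon, so the effect of a chloro, a methoxy or an amine there stays open. On these data alone, the effect of a longer chain also stays open.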